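Swapping Hydroxy for (Dimethylamino)methyl on a Shared Core

The compounds below may be only part of what the source reports. "The series", "measured", "known", "first", "only" and "open" are said of these compounds alone.

Compound 1, `CCOC(=O)c1cccc(-c2ccc(O)cc2)c1`: 77%
Compound 2, `CCOC(=O)c1cccc(-c2ccsc2)c1`: 67%

In an assay on COS-7 cells for inhibition of patatin-like phospholipase domain-containing protein 2 (Mus musculus), tested at 200 uM (a higher number here means more inhibition at the concentration tested (going by the name of the read-out), a lower number less inhibition), compound 1 gives 77%, the higher of the two numbers measured, while compound 2 gives 67%, a value that sits within the scatter of compound 1, so the two cannot be ranked. Compound 3, `CCOC(=O)c1cccc(-c2ccc(CN(C)C)cc2)c1`, is not yet measured. It differs from compound 1 by (dimethylamino)methyl in place of hydroxy on an aromatic carbon. Among the measured compounds shown here, no measured pair shows a step of this kind, so the data give no guide to its size. The step of a number 15 percentage points lower from compound 1 to compound 3 (beyond the scatter) is expected to be small and downward, at most just beyond the scatter. For compound 3 the estimate is 62%, within a range from 35% to 85%.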

Compound 3, a percentage reported as inhibition, at one concentration (the size of the read-out at that concentration, not a potency): 67%
The estimate for compound 3 lay 5 percentage points below the measured number; measured number inside the range.
By their numbers in this assay, from the lowest: compounds 2, 3 and 1 (each within the scatter of the next).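

In this assay, (dimethylamino)methyl in place of hydroxy on an aromatic carbon gives a number 10 percentage points lower from compound 1 to compound 3 (within the scatter). This position, para to a large group, therefore takes the larger group, which has no hydrogen-bond donor, with a step that stays within the scatter. Nothing measured here accounts for this result. What the compounds shown leave open is whether a carboxylic acid at this position, or a longer chain ending in the same dimethylamino group, would move the number beyond the scatter.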